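From fluoro to chloro on compound 2

This account rests on a few compounds, and the source may have more. Where it says the series, first, only, none or still open, it means among the compounds named here.

- compound 1 `C=C[C@@](C)(/C=C/c1ccc(O)c(CO)c1)CCC=C(C)C` gives > 36600 nM
- compound 2 `C=C[C@@](C)(/C=C/c1ccc(O)c(/C=C/c2ccc(F)cc2)c1)CCC=C(C)C` gives > 36600 nM

In an ADME assay on HEK293 cells (Homo sapiens) for cytotoxicity, with a stated time of 72 h (a lower number here means that less compound is needed, a higher number that more compound is needed for the effect), compound 1 gives > 36600 nM as a limit, not a number. Compound 2 gives > 36600 nM as a limit too. Together they show the limit of > 36600 nM in this assay, at which 2 of the 2 values shown sit, and nothing finer. Within the data shown here, the one measured step is a step that the two limits leave unreadable from compound 1 to compound 2 and offers no size to carry forward. Compound 3 `C=C[C@@](C)(/C=C/c1ccc(O)c(/C=C/c2ccc(Cl)cc2)c1)CCC=C(C)C` differs from compound 2 by chloro in place of fluoro on an aromatic carbon, with chloro in place of fluoro on an aromatic carbon. With no readable step behind it, no change beyond the scatter is expected in this assay here. The expected step is a number no higher from compound 2 to compound 3 (the limit leaves the size open) and may well end at a limit again. Compound 3 is estimated at 36600 nM, with an expected range from 15000 nM to 75000 nM.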

Compound 3, half-maximal effective concentration: > 36600 nM
Compound 3 was reported as a limit; the forecaster's own chance of this, stated with the estimate: 75%; the middle value sits exactly at the limit.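

No step can be read among compound 1, compound 2 and compound 3, since all three give the same reading: the limit of > 36600 nM in this assay, at which 3 of the 3 values shown sit.

The compounds shown leave open what concentration of each would reach the half-maximal effect in this assay, and so whether chloro and fluoro differ there at all.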